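Three Cytotoxicity Limits and a Trifluoromethoxy Exchange

The source may hold more compounds than are shown below. What is called first, only, known or untested is meant among the compounds shown, and "the series" means these compounds.

Compound 1 `Cc1cc(NC(=O)Nc2ncccc2C)c2ccccc2n1`: in an ADME assay on HEK293 cells (Homo sapiens) for cytotoxicity, with a stated time of 72 h (on this read-out lower numbers stand for an effect already at smaller amounts and higher numbers for an effect only at larger amounts of compound), compound 1 gives > 25000 nM, which is a limit of the assay.
Compound 2 `Cc1cc(NC(=O)Nc2ccc(N)cc2)c2ccccc2n1`: in this assay compound 2 gives > 25000 nM, again a limit rather than a number.
Compound 3 `Cc1cc(NC(=O)Nc2cccnc2)c2ccccc2n1`: in this assay compound 3 gives > 25000 nM, also a limit.

Compound 2 therefore stands where every measured compound stands, at the limit (the limit of > 25000 nM in this assay, at which 3 of the 3 values shown sit), so nothing separates it from compound 1 or compound 3 on the numbers shown. The steps a step that the two limits leave unreadable from compound 1 to compound 2, a step that the two limits leave unreadable from compound 1 to compound 3 and a step that the two limits leave unreadable from compound 2 to compound 3 are all unreadable for the same reason: both ends are limits.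

Compound 4 `Cc1cc(NC(=O)Nc2ccc(OC(F)(F)F)cc2)c2ccccc2n1` differs from compound 2 by trifluoromethoxy in place of amino on an aromatic carbon. The exchange sits on an aromatic carbon, para to a large group. The steps that touch compound 2, from compound 1 and to compound 3, bear on this change, yet neither has a readable size, so no direction beyond the scatter can be expected for the step of a number no higher from compound 2 to compound 4 (the limit leaves the size open).

Compound 4 is accordingly expected to sit near 25000 nM, within 8000 nM to 80000 nM, most probably as another limit.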

Compound 4, half-maximal effective concentration: 14000 nM
Compound 4: middle estimate off by 1.8-fold (0.25 log units), on the high side; the range from low to high includes it.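

For the compounds shown here, at this position, on an aromatic carbon para to a large group, trifluoromethoxy in place of amino gives in this assay the one step whose size can be read in part, unlike the earlier steps, which cannot be read: an at least 1.7-fold lower number from compound 2 to compound 4 (0.25 log units; that floor lies within the scatter). Compound 4 is also the only compound shown that carries a number and not a limit: the limit of > 25000 nM in this assay, at which 3 of the 4 values shown sit. The exchange removes the hydrogen-bond donor of the amino group and adds heavy atoms, yet this single pair cannot tell which of these differences goes with the step.

The compounds shown leave open whether methoxy, trifluoromethyl or a chlorine atom on this carbon would also give a number and not a limit. From the compounds shown here alone, it also remains open whether a number appears with any group lacking the amino hydrogens, or with trifluoromethoxy alone.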